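Thiophen-3-yl replacing pyrazin-2-yl on the shared core

The source may hold more compounds than are shown below. What is called first, only, known or untested is meant among the compounds shown, and "the series" means these compounds.

In a functional assay for activation of Alpha-1B adrenergic receptor (Homo sapiens), read by calcium flux (on this read-out lower numbers stand for smaller maximal responses and higher numbers for larger maximal responses), compound 1 `c1ccc(-c2cnccn2)c(OCC2=NCCN2)c1` gives 46%, the lowest of the three numbers measured. Compound 2 `c1csc(-c2ccccc2OCC2=NCCN2)c1` gives 112%, and compound 3 `c1c[nH]c(-c2ccccc2OCC2=NCCN2)c1` gives 104%. The change to compound 4 `c1ccc(-c2ccsc2)c(OCC2=NCCN2)c1` is thiophen-3-yl in place of pyrazin-2-yl on an aromatic carbon. Among the measured compounds shown here, two measured steps bear on it: a number 66 percentage points higher from compound 1 to compound 2 (beyond the scatter) and a number 58 percentage points higher from compound 1 to compound 3 (beyond the scatter), both large, and both exchange the pyrazin-2-yl for a five-membered aromatic ring with one hetero atom. The step of a number 8 percentage points lower from compound 2 to compound 3 (within the scatter) shows that those two five-membered rings give numbers within the scatter of each other. Because compound 1 gives 46% and thiophen-3-yl is also a five-membered aromatic ring with one hetero atom, a large rise is expected for compound 4, about a number 59 percentage points higher from compound 1 to compound 4 (beyond the scatter). Compound 4 is therefore estimated at 105%, between 75% and 130%.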

Compound 4, largest response reached (reported as maximum), in percent of the reference or control that the assay uses: 103%
Estimate against measurement, compound 4: 2 percentage points above, and the stated range covers the measured number.
By their numbers in this assay, from the lowest: compound 1; then compounds 4, 3 and 2 (each within the scatter of the next).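

In this assay, the large rise seen with thiophen-2-yl and 1H-pyrrol-2-yl recurs with thiophen-3-yl, a number 57 percentage points higher from compound 1 to compound 4 (beyond the scatter), so among these compounds it does not depend on which of the two thiophene attachments is present. The new compound also stays level with the other five-membered rings, with a number 1 percentage points lower from compound 3 to compound 4 (within the scatter) and a number 9 percentage points lower from compound 2 to compound 4 (within the scatter). No measurement at hand explains the gap to pyrazin-2-yl. The compounds shown leave open whether a phenyl or pyridin-3-yl ring at this place would match the five-membered rings or compound 1.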